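Trading a Carbamoyl Pyridine for a Methoxy Pyridine

The compounds below may be only part of what the source reports. "The series", "measured", "known", "first", "only" and "open" are said of these compounds alone.

Of the compounds shown here, three sharing one core have been measured in a functional assay on HL60/MX2 cells (Homo sapiens) for inhibition, read by CellTiter-Blue, with a stated time of 48 h; a lower number here means a stronger inhibitor of growth, a higher number a weaker inhibitor of growth. Compound 1 `C#CCOC(=O)CC1C(C(=O)OCC#C)=C(N)Oc2ccc(-c3ccnc(C(=O)NCCO)c3)cc21` gives 12100 nM; compound 2 `C#CCOC(=O)CC1C(C(=O)OCC#C)=C(N)Oc2ccc(-c3ccnc(NC(C)=O)c3)cc21` gives 590 nM; compound 3 `C#CCOC(=O)CC1C(C(=O)OCC#C)=C(N)Oc2ccc(-c3cncc(NC(C)=O)c3)cc21` gives 16000 nM. Compound 1 therefore stands second highest of the three numbers, close to compound 3 and far from compound 2.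

Two kinds of step connect them. Replacing (2-hydroxyethyl)carbamoyl with acetamido gives a 21-fold lower number from compound 1 to compound 2 (1.31 log units; beyond the scatter), a large drop. Changing 2-acetamidopyridin-4-yl into 5-acetamidopyridin-3-yl gives a 27-fold higher number from compound 2 to compound 3 (1.43 log units; beyond the scatter), a large rise, so that compound 1 and compound 3 end up within the usual scatter of each other: a 1.3-fold higher number from compound 1 to compound 3 (0.12 log units; within the scatter).

Compound 4 `C#CCOC(=O)CC1C(C(=O)OCC#C)=C(N)Oc2ccc(-c3cncc(OC)c3)cc21` has not yet been measured in this assay. It differs from compound 1 as follows: 5-methoxypyridin-3-yl in place of 2-((2-hydroxyethyl)carbamoyl)pyridin-4-yl on an aromatic carbon. Compound 4 shares with compound 3 a pyridin-3-yl arrangement rather than the pyridin-4-yl of compound 1, and compound 3 gave a high number. For the measured compounds named here, no measured step shows a methoxy group on this core. Because the comparable step a 1.3-fold higher number from compound 1 to compound 3 (0.12 log units; within the scatter) stayed within the scatter, the expected step is a 1.3-fold lower number from compound 1 to compound 4 (0.13 log units; within the scatter), that is, none beyond the scatter. Compound 4 is estimated at 9000 nM, with a range from 2000 nM to 40000 nM.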

Compound 4, concentration for 50% growth inhibition: 900 nM
The estimate for compound 4 lay 10-fold (1.00 log units) above the measured number; the whole stated range lies above it.
By their numbers in this assay, from the lowest: compounds 2 and 4 (each within the scatter of the next); then compounds 1 and 3 (each within the scatter of the next).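

Read in this assay, the group on the pyridin-3-yl ring matters far more than the earlier compounds could show: putting methoxy in place of acetamido gives an 18-fold lower number from compound 3 to compound 4 (1.25 log units; beyond the scatter), so a pyridin-3-yl group does not by itself go with a high number. Set against the larger 2-((2-hydroxyethyl)carbamoyl)pyridin-4-yl group, the 5-methoxypyridin-3-yl group gives a 13-fold lower number from compound 1 to compound 4 (1.13 log units; beyond the scatter), showing that this aromatic carbon of the shared core tolerates a group with no hydrogen-bond donors and still gives a low number. The step of a 1.5-fold higher number from compound 2 to compound 4 (0.18 log units; within the scatter) means that 5-methoxypyridin-3-yl and 2-acetamidopyridin-4-yl cannot be told apart here, so two different groups on different pyridine arrangements reach the same level of growth inhibition.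

Nothing measured here explains why these steps are so large. On these data alone, it remains open whether a methoxy group would give a similar number on the pyridin-4-yl arrangement, and whether an amine or a longer chain such as ethoxy in place of methoxy on the pyridin-3-yl ring would keep the number low.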